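Series notes: compound 3 expected from compounds 1 and 2

The compounds below may be only part of what the source reports. "The series", "measured", "known", "first", "only" and "open" are said of these compounds alone.

Compound 1 `CC1(C)[C@H]2CC[C@]1(C)N(Cc1cn(-c3ccccc3C#N)nn1)C(=O)C2` and compound 2 `CC1(C)[C@H]2CC[C@]1(C)N(Cc1cn(-c3ccc(F)cc3)nn1)C(=O)C2` share one core and differ only in the aryl group on an aromatic nitrogen of a five-membered aromatic ring with 3 nitrogen. In a functional assay on HepG2 cells (Homo sapiens) for inhibition, read by MTT assay, with a stated time of 24 h (a higher number here means a weaker inhibitor, a lower number a stronger inhibitor), compound 1 gives 180 nM, and in this assay compound 2 gives 90 nM. For the measured compounds named here, the step of a 2.0-fold lower number from compound 1 to compound 2 (0.30 log units; within the scatter) does not separate the two; compound 2 holds the lower of the two numbers, with compound 1 its only neighbour. Compound 3 `CC1(C)[C@H]2CC[C@]1(C)N(Cc1cn(-c3cccc(Br)c3)nn1)C(=O)C2` carries the change (3-bromophenyl in place of 4-fluorophenyl on an aromatic nitrogen). Going by the values given here, the sole measured step that bears on it is a 2.0-fold lower number from compound 1 to compound 2 (0.30 log units; within the scatter), another exchange of the aryl group at the same place, and that stayed within the scatter. No step beyond the scatter is therefore expected for compound 3 in this assay, in either direction, which is expressed as a 1.2-fold higher number from compound 2 to compound 3 (0.09 log units; within the scatter). Compound 3 is estimated at 110 nM in this assay, with an expected range from 40 nM to 300 nM.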

Compound 3, half-maximal inhibitory concentration: 20 nM
The estimate for compound 3 lay 5.5-fold (0.74 log units) above the measured number; the measured number lies below the stated range.
By their numbers in this assay, from the lowest: compound 3; then compounds 2 and 1 (each within the scatter of the next).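

In this assay the aryl group on the aromatic nitrogen now separates compounds, which the earlier pair did not show: 3-bromophenyl in place of 4-fluorophenyl gives a 4.5-fold lower number from compound 2 to compound 3 (0.65 log units; beyond the scatter), and 3-bromophenyl in place of 2-cyanophenyl gives a 9.0-fold lower number from compound 1 to compound 3 (0.95 log units; beyond the scatter). Both steps are modest but beyond the scatter, so this position does respond to the choice of aryl group, and compound 3 stands lowest of the three. The 4-fluorophenyl and 3-bromophenyl groups match in heavy-atom, donor and acceptor counts and differ in the halogen and its place, and nothing measured here bears on why the number moves.

The exchange changes the halogen and its place on the phenyl ring together, and the compounds shown do not separate the two. Also open, going by these compounds, is how an amine or a carboxylic acid on the phenyl ring would fare at this position.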